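This account rests on a few compounds, and the source may have more. Where it says the series, first, only, none or still open, it means among the compounds named here.

In an ADME assay on HEK293 cells (Homo sapiens) for cytotoxicity, read by resazurin assay, with a stated time of 48 h (on this read-out lower numbers stand for higher toxicity in this test and higher numbers for lower toxicity in this test), compound 2 (`CCCCCCCCC(=O)Nc1nc2ccccc2n1CCC`) gives > 83000 nM which is a limit, and so it stands at the limit of > 83000 nM in this assay, at which 2 of the 3 values shown sit, in this series. Compound 3 (`CCCn1c(NC(=O)/C=C/c2ccccc2)nc2ccccc21`) gives > 83000 nM which is also a limit. Compound 1 (`CCCCC(=O)Nc1nc2ccccc2n1CCC`) gives 2600 nM as a number. Compound 4 (`CCCn1c(NC(=O)CCc2ccccc2)nc2ccccc21`) departs from compound 2 (phenyl in place of hexyl on a saturated chain carbon, two bonds along the chain from a carbonyl carbon) with phenyl in place of hexyl on a saturated chain carbon, two bonds along the chain from a carbonyl carbon. For the measured compounds named here, the one measured step on this chain is large (an at least 31-fold higher number from compound 1 to compound 2 (1.50 log units; beyond the scatter)) and shows the shorter chain at the lower number. A moderate fall in this assay is therefore expected, with the estimated step of an at least 2.7-fold lower number from compound 2 to compound 4 (0.44 log units; beyond the scatter) as the likely size. For compound 4 the estimate is 30000 nM with an expected range from 5000 nM to 120000 nM in this assay.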

Compound 4, half-maximal cytotoxic concentration in the HEK293 assay: 14000 nM
Estimate against measurement, compound 4: 2.1-fold (0.33 log units) above; the range from low to high includes it.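

In the HEK293 assay the change gives an at least 5.9-fold lower number from compound 2 to compound 4 (0.77 log units; beyond the scatter), so at this place phenyl does not hold the high number seen with hexyl, although both groups count the same heavy atoms. It also gives a 5.4-fold higher number from compound 1 to compound 4 (0.73 log units; beyond the scatter), which places compound 4 on a measured number clear of the shorter-chain compound. In a physicochemical assay for lipophilicity (a lower number here means a more polar compound, a higher number a more lipophilic compound), compound 2 gives 5.7 and compound 4 gives 4.6. The change further yields a more polar compound: the measured partition coefficient of compound 2, 5.7, and of compound 4, 4.6, a number 1.10 log units lower (beyond the scatter)

Going by these compounds, whether the lower number follows the partition coefficient or the aromatic ring itself stays open from this single pair. On these data alone, how a pyridine ring or a carboxylic acid would read at this place also remains open.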